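A few compounds are considered here, and "the series" means these few. Any claim that something is new, unique, unknown or untested is made for them only; others in the source may bear on it.

Measured in a functional assay on the whole organism for inhibition, with Mus musculus as the target; a lower number here means that less compound is needed, a higher number that more compound is needed for the effect:
- compound 1 `CN1Cc2c(N)cccc2C(c2ccc(F)cc2)C1`: 0.25 mg/kg
- compound 2 `Cc1ccc(C2CN(C)Cc3c(N)cccc32)cc1`: about 1.2 mg/kg
- compound 3 `CC(C)c1ccc(C2CN(C)Cc3c(N)cccc32)cc1`: 68 mg/kg

Compound 2 holds the second highest of these three numbers. Compound 4 `CCCCNCC(=O)Nc1cccc2c1CN(C)CC2c1ccc(C)cc1` has not yet been measured in this assay, and it differs from compound 2 as follows: ((butylamino)methyl)carbonyl in place of hydrogen on a nitrogen on an aromatic ring. Among the measured compounds shown here, no measured step touches that nitrogen, so the evidence is only indirect. The available steps change a group on an aromatic carbon instead. There, a 4.8-fold higher number from compound 1 to compound 2 (0.68 log units; beyond the scatter) is modest, while a 57-fold higher number from compound 2 to compound 3 (1.75 log units; beyond the scatter) is large. These steps show that a single change can raise the number sharply in this small set. A clear rise is therefore expected, though its size is uncertain. The expected step is a 5.0-fold higher number from compound 2 to compound 4 (0.70 log units; beyond the scatter). For compound 4 the estimated value is 6 mg/kg, with an expected range from 1 mg/kg to 40 mg/kg.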

Compound 4, dose for half-maximal effect: about 2.5 mg/kg
Beside the measured number, compound 4's estimate is 2.4-fold (0.38 log units) above it; the range from low to high includes it.
By their numbers in this assay, from the lowest: compound 1; then compound 2; then compound 4; then compound 3.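

In this assay, among the compounds shown here, the nitrogen on the aromatic ring accepts a long ((butylamino)methyl)carbonyl group with only a small loss, a 2.1-fold higher number from compound 2 to compound 4 (0.32 log units; beyond the scatter), the first reading at this position. That modest step contrasts with the change on the aromatic carbon, a 57-fold higher number from compound 2 to compound 3 (1.75 log units; beyond the scatter), so a much larger addition need not cost more at every position. Nothing available explains the size of this step.

Only this one group is shown on the nitrogen, so it remains open how a simple acetyl group, a shorter chain or a terminal carboxylic acid would compare.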